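Hydroxy for methoxymethyl on the amine chain of compound 3

The source may report more compounds than this note shows. Statements on the series, on what has been measured and on what is new or still open speak of the compounds shown alone.

Measured so far:
compound 1, `COc1cc(/C=C/C2=CC(=O)CC(c3ccc(O)c(OC)c3)N2CCCO)ccc1O`, giving 95.6%
compound 2, `COc1cc(/C=C/C(=O)/C=C(/C=C/c2ccc(O)c(OC)c2)NCCCO)ccc1O`, giving 93.4%
compound 3, `COCCCNC(=C\C(=O)/C=C/c1ccc(O)cc1)/C=C/c1ccc(O)cc1`, giving 97%

In a functional assay on Caco-2 cells (Homo sapiens) for activation, read by fluorescence, tested at 1 uM (a lower number here means a stronger effect, a higher number a weaker effect of the compound at the concentration tested), the three measured compounds give numbers close to one another. Compound 3 holds the highest of the three numbers, but its gaps to compound 1 and to compound 2 both lie within the scatter, so no order among them can be read. Compound 4, `O=C(/C=C(/C=C/c1ccc(O)cc1)NCCO)/C=C/c1ccc(O)cc1`, is not yet measured. It differs from compound 3 in one place: hydroxy in place of methoxymethyl on a saturated chain carbon, two bonds along the chain from an amine nitrogen. Going by the values given here, no step between two measured compounds is available to show what such a change does here, and the measured numbers give no trend to lean on. The expected step is a number 2 percentage points lower from compound 3 to compound 4 (within the scatter), none beyond the scatter in this assay. Compound 4 is expected to give about 95%, within a range from 86% to 103%.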

Compound 4, a percentage reported as activity, at one concentration (the size of the read-out at that concentration, not a potency): 98.1%
Estimate against measurement, compound 4: 3.1 percentage points below; the measured number falls inside the stated range.
By their numbers in this assay, from the lowest: compounds 2, 1, 3 and 4 (each within the scatter of the next).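

In this assay, going by these compounds alone, the change from 3-methoxypropyl to 2-hydroxyethyl on the amine gives a number 1.1 percentage points higher from compound 3 to compound 4 (within the scatter), the only single-place step available. Exchanging methoxymethyl for hydroxy on this saturated chain carbon therefore leaves the read-out within the scatter at the concentration tested. Nothing available explains this result.

Open, on these data alone, is whether a carboxylic acid or a dimethylamino group at the end of this chain would give a step beyond the scatter. As far as these compounds go, a longer chain carrying the same hydroxy also remains open.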